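A Hydroxylated Amide Tail on a Chemokine Receptor Antagonist

A few compounds are considered here, and "the series" means these few. Any claim that something is new, unique, unknown or untested is made for them only; others in the source may bear on it.

Compound 2 `COc1c(F)ccc2c1c(NS(=O)(=O)c1ccc(Cl)s1)nn2Cc1cccc(CNC(C)=O)c1` gives 12.6 nM in a functional assay on CHO cells for antagonist activity at C-C chemokine receptor type 4 (Homo sapiens), read by GTPgammaS binding; on this read-out lower numbers stand for stronger inhibition and higher numbers for weaker inhibition. Within the data shown here, it stands lowest of the two compounds measured so far; compound 1 `CC(=O)NCc1cccc(Cn2nc(NS(=O)(=O)c3ccc(Cl)s3)c3c(Cl)cccc32)c1` gives 31.6 nM, a gap beyond the usual scatter. Compound 3 `COc1c(F)ccc2c1c(NS(=O)(=O)c1ccc(Cl)s1)nn2Cc1cccc(CNC(=O)C(C)(C)O)c1` keeps everything of compound 2 except the amide cap: 1-hydroxy-1-methylethyl in place of methyl on a carbonyl carbon. Among the measured compounds shown here, no measured pair shows this change, so its effect is unknown from these data. The step from compound 2 to compound 3 is expected to stay within the scatter, with no clear direction, a 1.1-fold lower number from compound 2 to compound 3 (0.02 log units; within the scatter). Compound 3 is therefore estimated at 12 nM, with a likely range from 4 nM to 40 nM.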

Compound 3, half-maximal inhibitory concentration in the C-C chemokine receptor type 4 assay: 39.8 nM
Beside the measured number, compound 3's estimate is 3.3-fold (0.52 log units) below it, within the range that was stated.
By their numbers in the C-C chemokine receptor type 4 assay, from the lowest: compound 2; then compounds 1 and 3 (each within the scatter of the next).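

On this amide cap the change is not silent: in the C-C chemokine receptor type 4 assay, 1-hydroxy-1-methylethyl in place of methyl on a carbonyl carbon gives a 3.2-fold higher number from compound 2 to compound 3 (0.50 log units; beyond the scatter), a modest weakening of inhibition. Nothing available explains this step. In a physicochemical assay for acid dissociation, compound 2 gives "not determined" (no result reported) and compound 3 gives "not determined" (no result reported), so no step can be read there.

Still open, going by these compounds, is whether the hydroxyl or the added carbons account for the step. A tert-butyl cap, which has the carbons without the hydroxyl, or a hydroxymethyl cap, which has the hydroxyl on a shorter group, could separate the two.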